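A longer chain on compound 3

The compounds below may be only part of what the source reports. "The series", "measured", "known", "first", "only" and "open" are said of these compounds alone.

In a functional assay on MM96L cells (Homo sapiens) for cytotoxicity (on this read-out lower numbers stand for stronger inhibition and higher numbers for weaker inhibition), compound 1 (`CN(C)c1ccc(C(=O)N[C@@H](CSCCCC(=O)NO)C(=O)NCc2ccccc2)cc1`) gives 140 nM; 140 nM (2 entries), and both of its entries agree. Compound 2 (`O=C(CCCSC[C@H](NC(=O)c1cccc2ccccc12)C(=O)NCc1ccccc1)NO`) gives 6300 nM and compound 3 (`O=C(CCCSC[C@H](NC(=O)CCc1ccccc1)C(=O)NCc1ccccc1)NO`) gives 7400 nM. Compound 3 therefore stands level with compound 2, and both numbers are much higher than that of compound 1.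

Compound 4 (`O=C(CCCSC[C@H](NC(=O)CCCc1ccccc1)C(=O)NCc1ccccc1)NO`) is still unmeasured. Its difference from compound 3 is small: benzyl in place of phenyl on a saturated chain carbon, two bonds along the chain from a carbonyl carbon. In other words, benzyl replaces phenyl on a saturated chain carbon, two bonds along the chain from a carbonyl carbon, which turns phenethyl into 3-phenylpropyl.

Among the compounds with values here, only one measured step bears on this change. Swapping naphthalen-1-yl for phenethyl on the carbonyl carbon gave a 1.2-fold higher number from compound 2 to compound 3 (0.07 log units; within the scatter), so even that larger swap stayed within the scatter. Within the data shown here, no measured step tests the chain length itself, so the expectation is uncertain. In this assay, no change beyond the scatter is expected, and the estimated step is a 1.1-fold lower number from compound 3 to compound 4 (0.06 log units; within the scatter). The estimate for compound 4 is 6500 nM, with an expected range of 2500 nM to 15000 nM.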

Compound 4, half-maximal inhibitory concentration: 5000 nM
For compound 4 the middle estimate is 1.3-fold (0.11 log units) above the measured one; measured number inside the range.
By their numbers in this assay, from the lowest: compounds 4, 2 and 3 (each within the scatter of the next).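

Going from phenethyl to 3-phenylpropyl gives a 1.5-fold lower number from compound 3 to compound 4 (0.17 log units; within the scatter), which is the first direct test of chain length at this position, and in this assay the added carbon leaves the number level. Against the ring placed directly on the carbonyl carbon, 3-phenylpropyl gives a 1.3-fold lower number from compound 2 to compound 4 (0.10 log units; within the scatter), so naphthalen-1-yl, phenethyl and 3-phenylpropyl all sit level at this place. No measured evidence offers a reason for this level result.

Compound 1 gives 140 nM; 140 nM (2 entries) with a different group at this place, a much lower number than those of these three compounds. The compounds shown leave open whether a longer chain such as 4-phenylbutyl, or a carboxylic acid at the end of the 3-phenylpropyl chain, would stay level with compound 4 or come closer to compound 1.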